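The compounds below may be only part of what the source reports. "The series", "measured", "known", "first", "only" and "open" are said of these compounds alone.

Measured compounds:
compound 1 `COC1NN=C(C[S+]([O-])C(c2ccccc2)c2ccccc2)S1` — 108000 nM
compound 2 `CC(C)c1nnsc1C[S+]([O-])C(c1ccccc1)c1ccccc1` — 69100 nM

In an assay on HEK293 cells for inhibition of sodium-dependent dopamine transporter (Homo sapiens), read by scintillation counting, with stated times of 5 min and 1 min (on this read-out higher numbers stand for weaker inhibition and lower numbers for stronger inhibition), compound 1 gives 108000 nM, and compound 2 gives 69100 nM. Compound 1 thus has the higher of the two numbers, but the step of a 1.6-fold lower number from compound 1 to compound 2 (0.19 log units; within the scatter) means the two compounds cannot be told apart on these data; both are very weak inhibitors.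

Compound 3 `Cc1nc(O)cc(C[S+]([O-])C(c2ccccc2)c2ccccc2)n1` is not yet measured. It differs from compound 1 in one place:
a group of 8 heavy atoms (5 carbon, 2 nitrogen, 1 oxygen; one six-membered aromatic ring with 2 hetero atoms) in place of a group of 7 heavy atoms (3 carbon, 2 nitrogen, 1 oxygen, 1 sulfur; one five-membered non-aromatic ring with 3 hetero atoms), on a saturated chain carbon bound to a sulfur

For the measured compounds named here, the only measured step that bears on this is the one from compound 1 to compound 2, where a different ring was likewise put in place of the same five-membered non-aromatic ring at the same saturated chain carbon bound to a sulfur, and the number moved by a 1.6-fold lower number from compound 1 to compound 2 (0.19 log units; within the scatter), within the scatter. The new ring of compound 3 is a six-membered aromatic one, which neither measured compound carries, so the basis for any prediction is thin. Going by the values given here, on the single comparable step, no change beyond the scatter is expected in this assay. Compound 3 is therefore estimated at 90000 nM (range 30000 nM to 300000 nM), a step of a 1.2-fold lower number from compound 1 to compound 3 (0.08 log units; within the scatter) that is expected to stay within the scatter.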

Compound 3, half-maximal inhibitory concentration: 3100 nM
For compound 3 the middle estimate is 29-fold (1.46 log units) above the measured one; measured number below the stated range.
By their numbers in this assay, from the lowest: compound 3; then compounds 2 and 1 (each within the scatter of the next).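

In this assay, the group on the saturated chain carbon bound to a sulfur proves able to shift the result by a wide margin: 6-hydroxy-2-methylpyrimidin-4-yl gives a 35-fold lower number from compound 1 to compound 3 (1.54 log units; beyond the scatter) and also a 22-fold lower number from compound 2 to compound 3 (1.35 log units; beyond the scatter) when it replaces 4-isopropyl-1,2,3-thiadiazol-5-yl. For the compounds shown here, the earlier pair gave no hint of this, since its single ring change stayed within the scatter, so that step alone had made the position look insensitive to which ring it carries, whereas compound 3 now stands as the strongest inhibitor of the three. Going by these compounds alone, nothing available here accounts for the gain, so the data show only that this ring change goes with a large step, not the reason for it.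

The three compounds cannot show which feature of the new group matters most, the hydroxy group, the methyl group or the six-membered aromatic ring with its two nitrogens, since these always appear together. From the compounds shown here alone, it also remains open whether an amine in place of the hydroxy group, or a longer chain in place of the methyl group, would keep, enlarge or lose this step.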